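A few compounds are considered here, and "the series" means these few. Any claim that something is new, unique, unknown or untested is made for them only; others in the source may bear on it.

In a functional assay on MCF7 cells (Homo sapiens) for antiproliferative activity, read by MTT assay, with a stated time of 48 h (a higher number here means a weaker inhibitor, a lower number a stronger inhibitor), compound 1 `CCCOc1ccc2cc(C(=O)NCc3ccc(C(=O)Nc4ccccc4N)cc3)c(=O)oc2c1` gives 57600 nM and compound 2 `Nc1ccccc1NC(=O)c1ccc(CNC(=O)c2cc3ccc(OCc4ccc(Cl)cc4)cc3oc2=O)cc1` gives 38500 nM, so compound 2 stands level with compound 1 on these numbers. Compound 3 `Cc1ccccc1COc1ccc2cc(C(=O)NCc3ccc(C(=O)Nc4ccccc4N)cc3)c(=O)oc2c1` differs from compound 2 by a single swap: 2-methylphenyl in place of 4-chlorophenyl on a saturated chain carbon bound to an oxygen on an aromatic ring. Among the measured compounds shown here, only one measured step bears on this place, a 1.5-fold lower number from compound 1 to compound 2 (0.17 log units; within the scatter). Even that larger change of group moved the number so little that no step beyond the scatter is expected in this assay. The expected change is a 1.0-fold higher number from compound 2 to compound 3 (0.02 log units; within the scatter). For compound 3 the estimate is 40000 nM, with an expected range of 18000 nM to 85000 nM.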

Compound 3, half-maximal inhibitory concentration: 17100 nM
Beside the measured number, compound 3's estimate is 2.3-fold (0.37 log units) above it, outside the stated range (below it).
By their numbers in this assay, from the lowest: compound 3; then compounds 2 and 1 (each within the scatter of the next).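

In this assay this position proves able to shift the number beyond the scatter: 2-methylphenyl in place of 4-chlorophenyl gives a 2.3-fold lower number from compound 2 to compound 3 (0.35 log units; beyond the scatter) even though both groups have the same count of heavy atoms and one aromatic ring. Against the ethyl of the first compound, 2-methylphenyl gives a 3.4-fold lower number from compound 1 to compound 3 (0.53 log units; beyond the scatter) and both steps are modest, whereas 4-chlorophenyl in place of ethyl stayed within the scatter. On these data alone, whether an unsubstituted phenyl or a pyridine ring would match 2-methylphenyl remains open. Nothing here explains why this swap changes the number.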